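Urea to amide, and the cost of losing the benzoyl

The source may hold more compounds than are shown below. What is called first, only, known or untested is meant among the compounds shown, and "the series" means these compounds.

Of the compounds shown here, three that share one core have been measured in a functional assay on A-375 cells (Homo sapiens) for antiproliferative activity, read by MTT assay, with a stated time of 48 h, in the presence of a further agent that is not named here (a higher number here means a weaker inhibitor, a lower number a stronger inhibitor), and a fourth awaits its number. Compound 1 `O=C(Nc1ccc(-n2ccc3c(NC(=O)c4ccccc4)nccc32)cc1)Nc1ccc(Cl)c(C(F)(F)F)c1` gives 2400 nM in this assay. Compound 2 `Nc1nccc2c1ccn2-c1ccc(NC(=O)Nc2ccc(Cl)c(C(F)(F)F)c2)cc1` differs from it in one place, (hydrogen in place of benzoyl on a nitrogen on an aromatic ring), and in this assay compound 2 gives 8000 nM; the step of a 3.3-fold higher number from compound 1 to compound 2 (0.52 log units; beyond the scatter). Compound 3 `O=C(Nc1ccc(-n2ccc3c(NC(=O)c4ccccc4)nccc32)cc1)c1ccc(Cl)c(C(F)(F)F)c1` carries a different core, the difference being (4-chloro-3-(trifluoromethyl)phenyl in place of (4-chloro-3-(trifluoromethyl)phenyl)amino on a carbonyl carbon), and in this assay compound 3 gives 16.4 nM, so that a 150-fold lower number from compound 1 to compound 3 (2.17 log units; beyond the scatter). Compound 3 stands lowest of the three numbers, and its step to each of the other two lies beyond the scatter.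

Compound 4 `Nc1nccc2c1ccn2-c1ccc(NC(=O)c2ccc(Cl)c(C(F)(F)F)c2)cc1` is the unmeasured member. It differs from compound 3 by hydrogen in place of benzoyl on a nitrogen on an aromatic ring, and this is the same change that separates compound 1 from compound 2, made on the core of compound 3 instead; the surroundings of the place are described in the same words for both pairs. Among the compounds with values here, the only measured instance of this change is the step of a 3.3-fold higher number from compound 1 to compound 2 (0.52 log units; beyond the scatter), which was modest and beyond the scatter, and there is no measured case on the core of compound 3 to show whether that core answers differently. Resting on that single precedent, compound 4 is expected to sit above compound 3 by about a 3.4-fold higher number from compound 3 to compound 4 (0.53 log units; beyond the scatter). The estimate for compound 4 in this assay is therefore 55 nM, with a plausible span from 20 nM to 160 nM.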

Compound 4, half-maximal inhibitory concentration: 3800 nM
Estimate against measurement, compound 4: 69-fold (1.84 log units) below; measured number above the stated range.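

Removing the benzoyl in this assay gives a 230-fold higher number from compound 3 to compound 4 (2.36 log units; beyond the scatter), and set beside the earlier step, the same change does not carry over in size from one core to the other: the same change on two cores in this assay, a 3.3-fold higher number (0.52 log units; beyond the scatter) from compound 1 to compound 2 and a 230-fold higher number (2.36 log units; beyond the scatter) from compound 3 to compound 4, 70-fold (1.84 log units) apart, beyond the scatter of two such steps

The direction is the same on both cores, with the higher number on the amino side each time, but the size of the step on the core of compound 1 proved no guide to its size on the core of compound 3; with the benzoyl gone, compound 2 gives 8000 nM and compound 4 gives 3800 nM. Within the data shown here, this rests on only two pairs in a single assay, so it shows that the step depends on the core, but it does not show why, or how the change would behave on any further core.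

The compounds shown carry only benzoyl or hydrogen on that nitrogen, so it remains open whether a smaller acyl group such as acetyl, or a simple alkyl group such as methyl, would keep a number near that of compound 3. From the compounds shown here alone, it also remains open whether a substituted benzoyl, for example one bearing a methoxy group or a fluorine, would shift that number in either direction.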